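The compounds below may be only part of what the source reports. "The series", "measured", "known", "first", "only" and "open" are said of these compounds alone.

Of the compounds shown here, two from this series have been measured so far. Compound 1 (`C/C=C(/C)C(=O)O[C@@H]1C=C(CO)C(=O)[C@@H](OC(=O)[C@]2(C)O[C@@H]2C)[C@@H]1C(C)C`) carries a ((2,3-dimethyloxiran-2-yl)carbonyl)oxy group on a saturated carbon of its core. In a functional assay on U-251 cells (Homo sapiens) for cytotoxicity, read by XTT assay, with a stated time of 72 h (on this read-out lower numbers stand for stronger inhibition and higher numbers for weaker inhibition), compound 1 gives 2900 nM. Among the measured compounds shown here, compound 2 (`C/C=C(/C)C(=O)O[C@@H]1C(=O)C(CO)=C[C@@H](OC(=O)/C(C)=C/C)[C@H]1C(C)C`) is the only other measured compound, and in this assay compound 2 gives 2100 nM. Compound 1 thus has the highest of the two numbers, but its gap to compound 2 lies within the scatter, so the two cannot be told apart. Compound 3 (`C/C=C(/C)C(=O)O[C@@H]1C=C(CO)C(=O)[C@@H](O)[C@@H]1C(C)C`) has not yet been measured. It differs from compound 1 in one place: hydrogen in place of (2,3-dimethyloxiran-2-yl)carbonyl on an oxygen on a saturated carbon. For the measured compounds named here, no step between two measured compounds is available to guide the size of this change, so the expectation rests on the structural change alone. For compound 3 the expected step is a 2.1-fold higher number from compound 1 to compound 3 (0.32 log units; beyond the scatter), which would mean weaker inhibition, with wide uncertainty. Compound 3 is therefore expected to give about 6000 nM in this assay, within a range from 2000 nM to 20000 nM.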

Compound 3, half-maximal inhibitory concentration: 4300 nM
The estimate for compound 3 lay 1.4-fold (0.14 log units) above the measured number, within the range that was stated.
By their numbers in this assay, from the lowest: compounds 2, 1 and 3 (each within the scatter of the next, the first and the last beyond it).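

In this assay, replacing the whole (2,3-dimethyloxiran-2-yl)carbonyl with hydrogen, which leaves a hydroxy on this saturated carbon, gives a 1.5-fold higher number from compound 1 to compound 3 (0.17 log units; within the scatter). Compound 1 and compound 3 therefore cannot be told apart, so this large group, with its three-membered ring, is not shown to matter for the read-out at this position, at least on the core of compound 1. Nothing available explains this result.

The compounds shown leave open whether a small acetyl group or a longer hexanoyl chain on this same oxygen would give a number beyond the scatter of compound 3. They also leave open whether a simple methyl ether there would differ from the free hydroxy.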